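Fluoro in Place of Methoxy at the Styryl End

The source may hold more compounds than are shown below. What is called first, only, known or untested is meant among the compounds shown, and "the series" means these compounds.

In a functional assay on HeLa cells (Homo sapiens) for cytotoxicity, read by WST assay, with a stated time of 48 h (a higher number here means a weaker inhibitor, a lower number a stronger inhibitor), compound 1 `CCCCCC/C=C/C[C@H]1C[C@@H]([C@@H](O)c2ccccc2)CO[C@@H]1c1ccccc1` gives 7400 nM, compound 2 `Oc1ccc(/C=C/C[C@H]2C[C@@H]([C@@H](O)c3ccccc3)CO[C@@H]2c2ccccc2)cc1` gives 14400 nM and compound 3 `COc1ccccc1/C=C/C[C@H]1C[C@@H]([C@@H](O)c2ccccc2)CO[C@@H]1c1ccccc1` gives 14700 nM. Compound 3 therefore lies within the scatter of both other compounds, and no order can be drawn among the three.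

Compound 4 `O[C@@H](c1ccccc1)[C@H]1CO[C@H](c2ccccc2)[C@@H](C/C=C/c2ccccc2F)C1` differs from compound 3 at one place: fluoro in place of methoxy on an aromatic carbon.

Among the measured compounds shown here, no measured step makes this exact exchange, so the evidence is indirect. The three changes measured at the same end of the molecule are a 1.9-fold higher number from compound 1 to compound 2 (0.29 log units; within the scatter), a 2.0-fold higher number from compound 1 to compound 3 (0.30 log units; within the scatter) and a 1.0-fold higher number from compound 2 to compound 3 (0.01 log units; within the scatter). Since even the replacement of hexyl in compound 1 stayed within the scatter, no step beyond the scatter is expected in this assay. The expected change is a 1.2-fold lower number from compound 3 to compound 4 (0.09 log units; within the scatter). For compound 4 the estimated value is 12000 nM, with an expected range from 6000 nM to 24000 nM.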

Compound 4, half-maximal inhibitory concentration: 9730 nM
Compound 4: the middle estimate sits 1.2-fold (0.09 log units) above what was measured; the range from low to high includes it.
By their numbers in this assay, from the lowest: compounds 1, 4, 2 and 3 (each within the scatter of the next).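

In this assay, fluoro in place of methoxy on this aromatic carbon, ortho to a large group, gives (a 1.5-fold lower number from compound 3 to compound 4 (0.18 log units; within the scatter)), so this smaller exchange within the 2-substituted phenyl group moves the number no further than the scatter. The 2-fluorophenyl group also stays within the scatter of the other two end groups (a 1.5-fold lower number from compound 2 to compound 4 (0.17 log units; within the scatter)) and (a 1.3-fold higher number from compound 1 to compound 4 (0.12 log units; within the scatter)), which extends the flat picture at this end of the molecule to a fourth compound. No measurement in hand accounts for this result.

The compounds shown leave open whether an amine or a carboxylic acid on this aromatic carbon, or a chain longer than hexyl, would move the number beyond the scatter. Nor do they include any change at this end of the molecule that does so.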